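This account rests on a few compounds, and the source may have more. Where it says the series, first, only, none or still open, it means among the compounds named here.

Two measured compounds set the frame. Compound 1 `Cc1c(OCCCCOc2ccccc2C(=O)O)ccc(C(=O)CC2CCCC2)c1C` and compound 2 `CC(=O)c1ccc(OCCCCOc2cccc(C(=O)O)c2C)c(C)c1O` share a core. In an assay on HEK293 cells for positive allosteric modulation of metabotropic glutamate receptor 2 (Rattus norvegicus), read by thallium flux, with a stated time of 2.5 min (on this read-out higher numbers stand for larger maximal responses and lower numbers for smaller maximal responses), compound 1 gives 67.1%, while compound 2 gives 79.2%, the higher of the two numbers, a gap beyond the scatter. Compound 3 `CCCC(=O)c1ccc(OCCCCOc2cccc(C(=O)O)c2C)c(C)c1O` has not been measured; it differs from compound 2 by ethyl in place of hydrogen on a saturated chain carbon bound to a carbonyl carbon. Going by the values given here, no pair of measured compounds shows what this change does here, so compound 3 is expected to move little from compound 2, if at all beyond the scatter. Compound 3 is estimated to reach 80% in this assay, within 65% to 95%. The step of a number 0.8 percentage points higher from compound 2 to compound 3 (within the scatter) is expected to stay within the scatter.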

Compound 3, largest response reached (reported as percent of maximum), in percent of the reference or control that the assay uses: 82.4%
Compound 3: middle estimate off by 2.4 percentage points, on the low side; the range from low to high includes it.
By their numbers in this assay, from the lowest: compound 1; then compounds 2 and 3 (each within the scatter of the next).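

In this assay, ethyl in place of hydrogen on a saturated chain carbon bound to a carbonyl carbon gives a number 3.2 percentage points higher from compound 2 to compound 3 (within the scatter). Going by these compounds alone, this is the first reading of this change, and it shows that the response of compound 3 cannot be told apart from that of compound 2, so acetyl and propylcarbonyl are equivalent on this read-out. On these data alone, whether a longer chain or an amine on this carbon would also leave the response in this assay within the scatter remains open. Nothing shown here explains the outcome at this position.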